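A Bromine Added to the Pendant Phenyl of Compound 3

The compounds below may be only part of what the source reports. "The series", "measured", "known", "first", "only" and "open" are said of these compounds alone.

Compound 3 `c1ccc(-c2ccnc3c2c(-c2ccccc2)nn3-c2ccccc2)cc1` was tested in a functional assay on HepG2 cells (Homo sapiens) for inhibition, read by MTT assay, with a stated time of 48 h (a higher number here means a weaker inhibitor, a lower number a stronger inhibitor), where compound 3 gives 3210 nM. Among the three measured compounds its number is the second highest. Its nearest neighbour is compound 1 `O=C(C=CNc1cc(-c2ccccc2)nn1-c1ccccc1)c1cccs1`, which in this assay gives 2420 nM; the two numbers lie within the scatter of each other, so no order between them is claimed. The furthest is compound 2 `O=C(C=CNc1cc(-c2ccccc2)nn1-c1ccccc1)c1ccc(Cl)cc1`, which in this assay gives 41200 nM, a gap beyond the scatter. Among the measured compounds shown here, the only single-change step among the measured compounds is a 17-fold higher number from compound 1 to compound 2 (1.23 log units; beyond the scatter); it concerns a group attached to a carbonyl carbon on a core that compounds 3 and 4 do not share.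

Compound 4 `Brc1ccc(-c2ccnc3c2c(-c2ccccc2)nn3-c2ccccc2)cc1` differs from compound 3 by bromo in place of hydrogen on an aromatic carbon. For the measured compounds named here, no measured step speaks to a halogen entering an aromatic carbon para to a large group, and the step from compound 1 to compound 2 involves different groups on a different core. With nothing that bears on the change, he expects no step beyond the scatter, and a 1.0-fold lower number from compound 3 to compound 4 (0.00 log units; within the scatter) is the estimated step. Compound 4 is therefore expected to give about 3200 nM in this assay, between 1200 nM and 9000 nM.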

Compound 4, half-maximal inhibitory concentration: 49900 nM
The estimate for compound 4 lay 16-fold (1.19 log units) below the measured number; measured number above the stated range.
By their numbers in this assay, from the lowest: compounds 1 and 3 (each within the scatter of the next); then compounds 2 and 4 (each within the scatter of the next).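

Phenyl to 4-bromophenyl on this core comes with a 16-fold higher number from compound 3 to compound 4 (1.19 log units; beyond the scatter) in this assay, so a single bromine atom on this aromatic carbon, para to a large group, is enough to turn the compound into a clearly weaker inhibitor. Among the compounds shown here, the earlier step, a 17-fold higher number from compound 1 to compound 2 (1.23 log units; beyond the scatter), was also large, but it concerned a group on a carbonyl carbon of a different core; this result is the first to show that the core of compound 3 responds strongly to a change on its pendant phenyl, and the two steps together support no general rule about halogens. No measurement at hand accounts for the size or the direction of this step.

As far as these compounds go, whether fluoro, an amine or a methoxy group on the same aromatic carbon would give a step of similar size remains open, and so the result cannot yet be assigned to bromo in particular rather than to any group at this position. Also open, from the compounds shown here alone, is whether bromo on either of the other two phenyl rings of compound 3 would have a comparable effect.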